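A few compounds are considered here, and "the series" means these few. Any claim that something is new, unique, unknown or untested is made for them only; others in the source may bear on it.

In a functional assay on KB cells (Homo sapiens), read by MTT assay (on this read-out lower numbers stand for stronger inhibition and higher numbers for weaker inhibition), compound 1 `CCC#C[C@@]1(O)[C@@H](CO)O[C@@H](n2ccc(N)nc2=O)[C@@H]1O` gives 108000 nM and compound 2 `CCC#C[C@@]1(O)[C@@H](CO)O[C@@H](n2ccc(=O)[nH]c2=O)[C@@H]1O` gives 226000 nM as the higher of these two numbers. Compound 3 `CCC[C@@]1(O)[C@@H](CO)O[C@@H](n2ccc(=O)[nH]c2=O)[C@@H]1O` gives > 350000 nM as a limit and not a number. Compound 4 `O=c1ccn([C@@H]2O[C@H](CO)[C@](O)(C3CC3)[C@H]2O)c(=O)[nH]1` differs from compound 2 by cyclopropyl in place of but-1-yn-1-yl on a saturated ring carbon in a single swap, cyclopropyl in place of but-1-yn-1-yl on a saturated ring carbon. Among the measured compounds shown here, with propyl in place of but-1-yn-1-yl the one measured step that bears on this is an at least 1.5-fold higher number from compound 2 to compound 3 (0.18 log units; that floor lies within the scatter) and so no step beyond the scatter is expected for the swap to cyclopropyl. The estimated step of a 1.2-fold higher number from compound 2 to compound 4 (0.09 log units; within the scatter) is a small one toward higher numbers. For compound 4 the estimate is 280000 nM with 150000 nM to 500000 nM as its expected range.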

Compound 4, half-maximal inhibitory concentration: > 350000 nM
Compound 4 ended at the assay's limit; the forecaster's own chance of this, stated with the estimate: 40%; middle value at least 1.2-fold (0.09 log units) from the limit.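

In this assay, replacing but-1-yn-1-yl with cyclopropyl gives an at least 1.5-fold higher number from compound 2 to compound 4 (0.18 log units; that floor lies within the scatter). A small carbon ring therefore behaves like the propyl chain of compound 3: both end without a number, so neither swap shows a loss beyond the scatter. The step between compound 3 and compound 4 cannot be read, because both sit at one limit: the limit of > 350000 nM in this assay, at which 2 of the 4 values shown sit.

On these data alone, how far past that limit either compound lies stays open. Also open, as far as these compounds go, is whether an amine or a longer chain with a triple bond on this ring carbon would give a readable number.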